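The compounds below may be only part of what the source reports. "The series", "measured", "known", "first", "only" and "open" are said of these compounds alone.

Compound 1 `Cc1cc(=O)n(-c2ccc(Br)cc2F)nc1C(=O)Nc1ccc(Oc2ncnc3sccc23)cc1` gives 6300 nM in a functional assay on HepG2 cells (Homo sapiens) for cytotoxicity, read by MTT assay, with a stated time of 72 h; on this read-out higher numbers stand for weaker inhibition and lower numbers for stronger inhibition. Compound 2 `Cc1ccc(-n2nc(C(=O)Nc3ccc(Oc4ncnc5sccc45)cc3)c(C)cc2=O)cc1` gives only a limit in this assay, > 40000 nM. Compound 3 `Cc1cc(=O)n(-c2ccc(F)cc2)nc1C(=O)Nc1ccc(Oc2ncnc3sccc23)cc1` gives 6460 nM in this assay.

Among the two numbers, compound 3 stands highest, and its nearest neighbour is compound 1, with a 1.0-fold higher number from compound 1 to compound 3 (0.01 log units; within the scatter), a gap within the scatter. The step away from compound 1 toward compound 2 was far larger, an at least 6.3-fold higher number from compound 1 to compound 2 (0.80 log units; beyond the scatter), and that from compound 2 to compound 3, an at least 6.1-fold lower number from compound 2 to compound 3 (0.79 log units; beyond the scatter), which follows from the limit (the limit of > 40000 nM in this assay, at which 1 of the 3 values shown sits).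

Compound 4 `Cc1cc(=O)n(-c2ccc(F)cc2)nc1C(=O)Nc1ccc(Oc2ncnc3sccc23)c(F)c1` differs from compound 3 by fluoro in place of hydrogen on an aromatic carbon. Going by the values given here, no measured step touches this ring; the measured steps alter the group on the aromatic nitrogen. Among the compounds with values here, the one halogen exchange on record, from compound 1 to compound 3, stayed within the scatter, so a single added fluoro is expected to move little. For compound 4 the expected step is a 1.1-fold lower number from compound 3 to compound 4 (0.03 log units; within the scatter), within the scatter. Compound 4 is thus estimated at 6000 nM, between 2500 nM and 15000 nM.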

Compound 4, half-maximal inhibitory concentration: 12500 nM
The estimate for compound 4 lay 2.1-fold (0.32 log units) below the measured number; low and high end bracket the measured number.
By their numbers in this assay, from the lowest: compounds 1, 3 and 4 (each within the scatter of the next). At a limit, above all of these: compound 2.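

Where the earlier compounds varied only the group on the aromatic nitrogen, compound 4 gives the first reading from a change elsewhere, on an aromatic carbon ortho to a large group and meta to a large group. In this assay, fluoro in place of hydrogen at this carbon gives a 1.9-fold higher number from compound 3 to compound 4 (0.29 log units; within the scatter), so this single atom does not move the number beyond the scatter. Nothing on record bears on this step or offers a reason for its size.

On these data alone, it remains open how a larger or charged group at this carbon, such as methoxy or an amine, would read in this assay. Also open, as far as these compounds go, is whether fluoro here would give a similar step with the 4-bromo-2-fluorophenyl group of compound 1 on the aromatic nitrogen.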